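The compounds below may be only part of what the source reports. "The series", "measured", "known", "first", "only" and "open" are said of these compounds alone.

The measured compounds in this series are:

compound 1 `C=CCNc1nnc(SCC(=O)N(Cc2cccc([N+](=O)[O-])c2)c2ccc(F)cc2)s1`, with 32.7%
compound 2 `COCCNc1nnc(SCC(=O)N(Cc2cccc([N+](=O)[O-])c2)c2ccc(F)cc2)s1`, with 34.8%
compound 3 `CCCNc1nnc(SCC(=O)N(Cc2cccc([N+](=O)[O-])c2)c2ccc(F)cc2)s1`, with 25.1%

In an assay on isolated protein for inhibition of Amine oxidase [flavin-containing] A (Homo sapiens), read by fluorescence and Amplex Red, with a stated time of 30 min, tested at 0.01 uM (on this read-out lower numbers stand for a weaker effect and higher numbers for a stronger effect at the one concentration tested), compound 1 gives the second highest of the three numbers, though neither gap around it goes beyond the scatter. Its nearest neighbour is compound 2, reached through a number 2.1 percentage points higher from compound 1 to compound 2 (within the scatter), and its furthest is compound 3, reached through a number 7.6 percentage points lower from compound 1 to compound 3 (within the scatter). The third pair behaves the same way, with a number 9.7 percentage points lower from compound 2 to compound 3 (within the scatter). All three compounds share the same core and differ only in the group on the saturated chain carbon bound to the nitrogen on the aromatic ring.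

Compound 4 `CCNc1nnc(SCC(=O)N(Cc2cccc([N+](=O)[O-])c2)c2ccc(F)cc2)s1` has not yet been measured in this assay. It differs from compound 1 as follows: methyl in place of vinyl on a saturated chain carbon bound to a nitrogen on an aromatic ring

Among the measured compounds shown here, the step that bears most directly on this change is the one from compound 1 to compound 3, where ethyl took the place of vinyl at the same position and the number moved by a number 7.6 percentage points lower from compound 1 to compound 3 (within the scatter), within the scatter. The step to compound 2 was likewise within the scatter. No change at this position has so far produced a step beyond the scatter, so compound 4 is expected to show no step beyond the scatter, with a number 4.7 percentage points lower from compound 1 to compound 4 (within the scatter). Compound 4 is therefore estimated at 28%, within a range from 16% to 40%.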

Compound 4, a percentage reported as inhibition, at one concentration (the size of the read-out at that concentration, not a potency): 30.3%
Estimate against measurement, compound 4: 2.3 percentage points below; the range from low to high includes it.
By their numbers in this assay, from the lowest: compounds 3, 4, 1 and 2 (each within the scatter of the next).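

With compound 4, the chain on the nitrogen is shortened from allyl to ethyl, and in this assay the step of a number 2.4 percentage points lower from compound 1 to compound 4 (within the scatter) shows that this change, like the earlier ones, does not move the number beyond the scatter. The two further comparisons extend this to a shorter chain: taking one carbon off the propyl chain gives a number 5.2 percentage points higher from compound 3 to compound 4 (within the scatter) and removing the methoxy group from the 2-methoxyethyl chain gives a number 4.5 percentage points lower from compound 2 to compound 4 (within the scatter), so all four small chains in the series now read alike, whether or not they carry a double bond or an ether oxygen. Nothing at hand bears on why this position tolerates these changes.

The compounds shown stop at small open chains, so they leave open whether a longer chain such as hexyl, a ring such as phenyl or cyclohexyl, a carboxylic acid or a second amine on the chain, or the bare amino group would give a step beyond the scatter. Because the read-out comes from a single concentration, they also leave open whether these four compounds would match in potency.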